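The source may hold more compounds than are shown below. What is called first, only, known or untested is meant among the compounds shown, and "the series" means these compounds.

Compound 1 `O=C(NCCCCc1ccccc1)n1c(=O)oc2ccccc21` is the point of departure. In an assay on HEK293 cells for inhibition of acid ceramidase (Homo sapiens), with a stated time of 10 min (a lower number here means a stronger inhibitor, a higher number a weaker inhibitor), compound 1 gives 64 nM. Among the compounds with values here, only one other compound has been measured: compound 2 `COc1ccc(-c2ccc3oc(=O)n(C(=O)NCCCCc4ccccc4)c3c2)cc1`, which in this assay gives 67 nM. Compound 1 thus stands level with compound 2, the two numbers lying within the usual scatter of each other.

Compound 3 `O=C(NCCCCc1ccccc1)n1c(=O)oc2cc(-c3ccccc3)ccc21` is not yet measured. It differs from compound 1 by phenyl in place of hydrogen on an aromatic carbon.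

Within the data shown here, the one measured step that bears on this change is a 1.0-fold higher number from compound 1 to compound 2 (0.02 log units; within the scatter), where a related aromatic group entered at the same place on the core. That step was flat. The change to compound 3 is of the same kind, so no step beyond the scatter is expected in this assay, in either direction. The estimate that this means is a 1.0-fold higher number from compound 1 to compound 3 (0.01 log units; within the scatter), and compound 3 is therefore expected to give about 65 nM, with a range from 30 nM to 140 nM.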

Compound 3, half-maximal inhibitory concentration in the acid ceramidase assay: 84 nM
The estimate for compound 3 lay 1.3-fold (0.11 log units) below the measured number, within the range that was stated.
By their numbers in the acid ceramidase assay, from the lowest: compounds 1, 2 and 3 (each within the scatter of the next).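

With phenyl too, the number in the acid ceramidase assay stays flat: compound 3 gives 84 nM, a 1.3-fold higher number from compound 1 to compound 3 (0.12 log units; within the scatter), so this aromatic carbon has now taken two different aromatic groups without a step beyond the scatter. The new information comes from a second read-out: in a physicochemical assay for metabolic stability, read by HPLC, in phosphate buffer, at pH 7.4, tested at 10 uM (on this read-out higher numbers stand for a longer-lived compound and lower numbers for a shorter-lived compound), compound 1 gives 0.75 h, and the same change gives an at least 6.6-fold higher number from compound 1 to compound 3 (0.82 log units; beyond the scatter). In the physicochemical assay, compound 3 gives > 5 h, which is a limit of the assay and not a number, so the full size of this step remains unknown: the limit of > 5 h in the physicochemical assay, at which 1 of the 2 values shown sits.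

From the compounds shown here alone, it remains open whether a non-aromatic group on this carbon, such as an amine, a carboxylic acid or a longer carbon chain, would also leave the number in the acid ceramidase assay flat. Going by these compounds, how such groups would fare in the physicochemical assay is equally open.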